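Adding a halogenated benzyloxy group to compound 1

This account rests on a few compounds, and the source may have more. Where it says the series, first, only, none or still open, it means among the compounds named here.

Compound 1 `CCOC(=O)c1[nH]c(-c2cccc(C#N)c2)nc1C` is the starting point. In a functional assay on a cell-free system (plasma, Oryctolagus cuniculus) for inhibition, with stated times of 5 min, 1 min and 6 min (a higher number here means a weaker inhibitor, a lower number a stronger inhibitor), compound 1 gives only a limit of the assay, > 30000 nM, not a number. Compound 2 `CCOC(=O)c1c(C)nc(-c2cccc(C#N)c2)n1OCc1ccc(Cl)cc1` carries (4-chlorobenzyl)oxy on the aromatic nitrogen, and in this assay compound 2 gives 6830 nM. The step of an at least 4.3-fold lower number from compound 1 to compound 2 (0.64 log units; beyond the scatter) is known only as a minimum because one end sits at the limit (the limit of > 30000 nM in this assay, at which 1 of the 2 values shown sits). Compound 3 `CCOC(=O)c1c(C)nc(-c2cccc(C#N)c2)n1OCc1ccc(Br)cc1` differs from compound 1 by (4-bromobenzyl)oxy in place of hydrogen on an aromatic nitrogen. Among the measured compounds shown here, the step from compound 1 to compound 2 is the only guide, so a step of similar size toward a lower number in this assay is expected: an at least 5.0-fold lower number from compound 1 to compound 3 (0.69 log units; beyond the scatter). Compound 3 is therefore estimated at 6000 nM, between 2500 nM and 15000 nM.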

Compound 3, half-maximal inhibitory concentration: 24600 nM
For compound 3 the middle estimate is 4.1-fold (0.61 log units) below the measured one, and the stated range ends below it.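

In this assay, exchanging one halogen changes the result: the step is a 3.6-fold higher number from compound 2 to compound 3 (0.56 log units; beyond the scatter), so a bromo group cannot simply stand in for chloro in this substituent. For (4-bromobenzyl)oxy on the aromatic nitrogen, all that can be stated is an at least 1.2-fold lower number from compound 1 to compound 3 (0.08 log units; that floor lies within the scatter). That figure is only a floor because one end of the step is not a number: the limit of > 30000 nM in this assay, at which 1 of the 3 values shown sits.

The compounds shown leave open how an unsubstituted benzyloxy group or a 4-fluorobenzyloxy group would behave on this nitrogen. They also leave open whether a small methoxy group there would give any such step.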